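A Methoxy for Chloro on the Shared Core

This account rests on a few compounds, and the source may have more. Where it says the series, first, only, none or still open, it means among the compounds named here.

Compound 1 `COc1cc(-c2cc(-c3ccc(Cl)cc3)nc(-c3ccccc3)n2)cc(OC)c1OC` is the only one of the three measured compounds that gives a number in a functional assay on HT-29 cells (Homo sapiens) for inhibition, read by MTT assay, with a stated time of 48 h (on this read-out higher numbers stand for weaker inhibition and lower numbers for stronger inhibition), where compound 1 gives 6230 nM. The value of compound 2 `COc1cc(-c2cc(-c3cccc([N+](=O)[O-])c3)nc(-c3ccccc3)n2)cc(OC)c1OC` in this assay is a limit of the assay, > 25000 nM. Compound 3 `COc1cc(-c2cc(-c3cccc(O)c3)nc(-c3ccccc3)n2)cc(OC)c1OC` likewise returns a limit in this assay, > 25000 nM. Both steps away from compound 1 run toward that limit: an at least 4.0-fold higher number from compound 1 to compound 2 (0.60 log units; beyond the scatter), and an at least 4.0-fold higher number from compound 1 to compound 3 (0.60 log units; beyond the scatter), while a step that the two limits leave unreadable from compound 2 to compound 3. Compound 4 `COc1ccc(-c2cc(-c3cc(OC)c(OC)c(OC)c3)nc(-c3ccccc3)n2)cc1` differs from compound 1 by methoxy in place of chloro on an aromatic carbon. Within the data shown here, no measured step makes this exchange; the two that reach the limit swap the 4-chlorophenyl for 3-nitrophenyl or 3-hydroxyphenyl, so they bear on compound 4 only loosely, as a sign that departures from the 4-chlorophenyl of compound 1 have so far weakened inhibition in this assay, as far as the limit of > 25000 nM in this assay, at which 2 of the 3 values shown sit, lets one read. A modest step toward a higher number is therefore expected, a 1.9-fold higher number from compound 1 to compound 4 (0.28 log units; within the scatter). Compound 4 is estimated at 12000 nM, between 4000 nM and 40000 nM.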

Compound 4, half-maximal inhibitory concentration: 4230 nM
The estimate for compound 4 lay 2.8-fold (0.45 log units) above the measured number; the measured number falls inside the stated range.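

In this assay, methoxy on the aromatic carbon para to a large group reads no differently from chloro, which makes it a second group at this place that returns a number: a 1.5-fold lower number from compound 1 to compound 4 (0.17 log units; within the scatter). The 4-methoxyphenyl also stands clear of the 3-hydroxyphenyl and the 3-nitrophenyl, with an at least 5.9-fold lower number from compound 3 to compound 4 (0.77 log units; beyond the scatter) and an at least 5.9-fold lower number from compound 2 to compound 4 (0.77 log units; beyond the scatter), so leaving the 4-chlorophenyl does not by itself weaken inhibition. Both of these steps are open-ended, since their far ends are limits and not numbers: the limit of > 25000 nM in this assay, at which 2 of the 4 values shown sit.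

The compounds shown leave open whether the group itself or its place on the phenyl decides the result, as no group appears at both places. Also open, going by these compounds, is how an amine, a carboxylic acid or a longer chain would read in the place of the methoxy.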